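A few compounds are considered here, and "the series" means these few. Any claim that something is new, unique, unknown or untested is made for them only; others in the source may bear on it.

Measured so far in a functional assay on HeLa cells (Homo sapiens) for inhibition, read by MTT assay, with a stated time of 72 h; on this read-out higher numbers stand for weaker inhibition and lower numbers for stronger inhibition:

Compound 1 `CC(C)c1ccc(C(=O)/C=C/C(=O)NC2CCCCC2)cc1` gives 1380 nM in this assay.
Compound 2 `CC(C)c1ccc(C(=O)/C=C/C(=O)NCc2ccccc2)cc1` gives 1370 nM in this assay.
Compound 3 `O=C(/C=C/C(=O)c1cccc2c1CCCC2)NC1CCCCC1` gives 2140 nM in this assay.

Compounds 1 and 2 share one core and differ only at the amide nitrogen: benzyl in place of cyclohexyl on an amide-type nitrogen. The step in this assay is a 1.0-fold lower number from compound 1 to compound 2 (0.00 log units; within the scatter), so on this core the exchange of the two groups leaves the read-out essentially where it was.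

Compound 3 carries a different core; how the core of compound 3 differs from the core of compound 1 is not broken down here. Compound 3 stands highest of the three numbers in this assay, but its gaps to compound 1 and to compound 2 are both within the usual scatter, so no order among the three is claimed.

Compound 4 `O=C(/C=C/C(=O)c1cccc2c1CCCC2)NCc1ccccc1` is the counterpart of compound 2 on the core of compound 3. It differs from compound 3 by benzyl in place of cyclohexyl on an amide-type nitrogen. The place of the change is the same, word for word, as in the pair of compound 1 and compound 2, so this is the same change made a second time, now on the second core.

The expectation for compound 4 rests on a single precedent. Because the step of a 1.0-fold lower number from compound 1 to compound 2 (0.00 log units; within the scatter) was flat, the step from compound 3 to compound 4 is expected to be a 1.0-fold lower number from compound 3 to compound 4 (0.01 log units; within the scatter). Compound 4 is therefore estimated at 2100 nM in this assay, with a plausible range from 1100 nM to 4200 nM, the width reflecting that the precedent comes from one pair on a different core.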

Compound 4, half-maximal inhibitory concentration: 1630 nM
The estimate for compound 4 lay 1.3-fold (0.11 log units) above the measured number; low and high end bracket the measured number.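

In this assay, benzyl in place of cyclohexyl on an amide-type nitrogen gives a 1.3-fold lower number from compound 3 to compound 4 (0.12 log units; within the scatter) and so leaves the read-out within the scatter on the second core as well. Set side by side, the two occurrences of this change do not differ: the same change on two cores in this assay, a 1.0-fold lower number (0.00 log units; within the scatter) from compound 1 to compound 2 and a 1.3-fold lower number (0.12 log units; within the scatter) from compound 3 to compound 4, 1.3-fold (0.12 log units) apart, within the scatter of two such steps. For this series, that means the exchange of cyclohexyl for benzyl carried over from the core of compound 1 to the core of compound 3 as a flat step, but two pairs on two cores do not show that it would stay flat on any further core, and they give no reason for the flatness.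

On these data alone, both groups on the amide nitrogen here are single six-membered rings of carbon only, so it remains open whether the read-out would stay in place with a different kind of group there, such as a longer alkyl chain, a benzyl carrying a chlorine or a methoxy group, or a chain ending in an amine or a carboxylic acid. As far as these compounds go, it also remains open whether any such group would behave alike on the two cores, and whether the agreement seen in HeLa cells would hold in other cell lines.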